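Piperidinyl-piperidine sulfonamides: removing the alkynyl ketone chain

The compounds below may be only part of what the source reports. "The series", "measured", "known", "first", "only" and "open" are said of these compounds alone.

Compound 3 `C#CCCC(=O)CC1CCN(C2CCN(S(=O)(=O)c3c(C)cc(C)cc3C)CC2)CC1` gives the lowest number of the three measured compounds in a functional assay on DLD-1 cells (Homo sapiens) for antiproliferative activity, read by CellTiter-Glo, with a stated time of 72 h (on this read-out lower numbers stand for stronger inhibition and higher numbers for weaker inhibition), at 3 nM. The nearest is compound 2 `Cc1cc(C)c(S(=O)(=O)N2CCC(N3CC(C)CC(C)C3)CC2)c(C)c1`, which in this assay gives 17 nM; furthest is compound 1 `Cc1ccc(C2CCN(S(=O)(=O)c3c(C)cc(C)cc3C)CC2)cc1`, which gives 2200 nM. For the measured compounds named here, the one single-point step measured so far is a 130-fold lower number from compound 1 to compound 2 (2.11 log units; beyond the scatter), showing that a saturated amine ring on the saturated ring carbon is tied to a far stronger read-out than an aryl group there.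

Compound 4 `Cc1cc(C)c(S(=O)(=O)N2CCC(N3CCCCC3)CC2)c(C)c1` differs from compound 3 only in that (hydrogen in place of ((but-3-yn-1-yl)carbonyl)methyl on a saturated ring carbon). Compound 4 keeps the amine ring that carries the large step from compound 1 to compound 2, and it is also compound 2 stripped of both ring methyls. Going by the values given here, no measured step speaks directly to the alkynyl ketone chain; its only reference is the gap between compound 2 and compound 3, with compound 2 at 17 nM and compound 3 at 3 nM. A modest weakening beyond the scatter, toward the value of compound 2, is therefore expected, a 6.7-fold higher number from compound 3 to compound 4 (0.82 log units; beyond the scatter). Compound 4 is accordingly estimated at 20 nM, within a range of 6 nM to 70 nM.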

Compound 4, half-maximal inhibitory concentration: 2200 nM
Compound 4: the middle estimate sits 110-fold (2.04 log units) below what was measured, and the stated range ends below it.
By their numbers in this assay, from the lowest: compound 3; then compound 2; then compounds 1 and 4 (each within the scatter of the next).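

The plain piperidin-1-yl ring does not account for the low numbers in this assay: replacing 4-methylphenyl with it gives a result level with the aryl compound (no change at the digits printed from compound 1 to compound 4 (within the scatter)), while removing the two ring methyls from the 3,5-dimethylpiperidin-1-yl group costs nearly all of the earlier step (a 130-fold higher number from compound 2 to compound 4 (2.11 log units; beyond the scatter)). The large step from compound 1 to compound 2 therefore cannot be read as an effect of a saturated amine ring alone, and the substituents on that ring are tied to the low numbers, as the ((but-3-yn-1-yl)carbonyl)methyl group also shows: hydrogen on this saturated ring carbon, three ring bonds from the ring nitrogen, gives a large loss (a 730-fold higher number from compound 3 to compound 4 (2.87 log units; beyond the scatter)). Nothing on hand explains why these substituents matter so much.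

The compounds shown leave open whether a single methyl on the piperidin-1-yl ring would be enough to restore the read-out. They also leave open which part of the chain matters, since a plain butyl chain or a chain ending in a hydroxyl group would separate the carbonyl and the triple bond from simple bulk on this carbon.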